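The source may hold more compounds than are shown below. What is called first, only, known or untested is meant among the compounds shown, and "the series" means these compounds.

Compound 1 `CC[C@]1(c2cccc([N+](=O)[O-])c2)OC[C@H]([C@@H]2CCCCN2)O1` and compound 2 `CC[C@]1(c2cccc(N)c2)OC[C@H]([C@@H]2CCCCN2)O1` share one core and differ only at the aromatic carbon. In a functional assay (brain) for displacement of a labelled ligand, with Rattus norvegicus as the target (on this read-out lower numbers stand for stronger inhibition and higher numbers for weaker inhibition), compound 1 gives 1320 nM, and compound 2 gives 1230 nM; the change a 1.1-fold lower number from compound 1 to compound 2 (0.03 log units; within the scatter) stays within the scatter, so compound 2 holds the lower of the two numbers without any claim of order. Compound 3 `CC[C@]1(c2cccc(N=C=S)c2)OC[C@H]([C@@H]2CCCCN2)O1` carries a group of 3 heavy atoms (1 carbon, 1 nitrogen, 1 sulfur; no ring) in place of one nitrogen atom, on an aromatic carbon. Going by the values given here, the only step bearing on this position is the one from compound 1 to compound 2, and it was flat, so no movement beyond the scatter is expected, with wide uncertainty given the unrelated entering group. Compound 3 is estimated at 1300 nM (range 400 nM to 4500 nM), an expected step of a 1.1-fold higher number from compound 2 to compound 3 (0.02 log units; within the scatter).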

Compound 3, inhibition constant: 590 nM
Beside the measured number, compound 3's estimate is 2.2-fold (0.34 log units) above it; the range from low to high includes it.
By their numbers in this assay, from the lowest: compound 3; then compounds 2 and 1 (each within the scatter of the next).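

The aromatic carbon is not indifferent to its substituent in this assay: the entering group of carbon, nitrogen and sulfur gives a 2.1-fold lower number from compound 2 to compound 3 (0.32 log units; beyond the scatter) and a 2.2-fold lower number from compound 1 to compound 3 (0.35 log units; beyond the scatter), both modest steps, whereas the amino and nitro groups lie within the scatter of each other. Nothing available explains these steps.

Open, as far as these compounds go, is whether the step belongs to this particular group or would also appear with other replacements on the same aromatic carbon, such as a thiourea, an acetamide or a methyl group. Also open, from the compounds shown here alone, is whether the step would carry over to the other stereoisomers of the shared core.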